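This account rests on a few compounds, and the source may have more. Where it says the series, first, only, none or still open, it means among the compounds named here.

Of the compounds shown here, three have so far been measured in a functional assay on HepG2 cells (Mus musculus) for antiproliferative activity against HepG2 (Homo sapiens), read by MTT assay, with a stated time of 48 h; a lower number here means a stronger inhibitor, a higher number a weaker inhibitor. Compound 1 `COc1cccc(C(=O)Nc2nnc(/C=C/c3cc(OC)c(OC)c(OC)c3Br)s2)c1` gives 120 nM in this assay, and compound 2 `COc1ccc(C(=O)Nc2nnc(/C=C/c3cc(OC)c(OC)c(OC)c3Br)s2)cc1` gives 220 nM in this assay. These two share one core and differ only by 3-methoxyphenyl in place of 4-methoxyphenyl on a carbonyl carbon, a change that made a 1.8-fold lower number from compound 2 to compound 1 (0.26 log units; within the scatter), so the two numbers cannot be told apart with confidence.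

Compound 3 `COc1ccc(/C=C/c2nnc(NC(=O)c3cc(OC)c(OC)c(OC)c3Br)s2)cc1` is built on a different core; the difference between the two cores is not broken down here. In this assay compound 3 gives 210 nM, a number close to that of compound 2.

Compound 4 `COc1cccc(/C=C/c2nnc(NC(=O)c3cc(OC)c(OC)c(OC)c3Br)s2)c1` has not yet been measured. It differs from compound 3 by 3-methoxyphenyl in place of 4-methoxyphenyl on a double-bonded chain carbon bound to a double-bonded chain carbon. Among the compounds with values here, this is the same kind of change as the one from compound 2 to compound 1, but not the same change: there it sat on a carbonyl carbon whose other neighbours are an amide-type nitrogen, whereas here it sits on a double-bonded chain carbon bound to a double-bonded chain carbon.

Because the step of a 1.8-fold lower number from compound 2 to compound 1 (0.26 log units; within the scatter) stayed within the scatter, the step from compound 3 to compound 4 is expected to be of similar size, around a 1.4-fold lower number from compound 3 to compound 4 (0.15 log units; within the scatter). Compound 4 is therefore expected to give roughly 150 nM in this assay, most likely between 70 nM and 320 nM.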

Compound 4, half-maximal inhibitory concentration: 210 nM
The estimate for compound 4 lay 1.4-fold (0.15 log units) below the measured number; measured number inside the range.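

In this assay, putting 3-methoxyphenyl in place of 4-methoxyphenyl on a double-bonded chain carbon bound to a double-bonded chain carbon gave no change at the digits printed from compound 3 to compound 4 (within the scatter). Set beside the same swap made on a carbonyl carbon in the other core, the two steps cannot be told apart: the same change on two cores in this assay, a 1.8-fold lower number (0.26 log units; within the scatter) from compound 2 to compound 1 and no change at the digits printed (within the scatter) from compound 3 to compound 4, 1.8-fold (0.26 log units) apart, within the scatter of two such steps This shows that, in these two pairs, the swap produced no step beyond the usual scatter on either core, but it does not show that a real effect carries from one core to the other, since neither step is large enough to count as an effect, and two pairs in one assay say nothing about further cores.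

The compounds shown carry only a methoxy group on this phenyl ring, so it remains open whether an amine or a carboxylic acid in its place would move the number beyond the scatter on either core. All four compounds also share the same brominated trimethoxyphenyl ring, which leaves open what a chlorine or a plain hydrogen in place of the bromine would do.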